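A few compounds are considered here, and "the series" means these few. Any claim that something is new, unique, unknown or untested is made for them only; others in the source may bear on it.

Measured compounds:
compound 1, `COc1ccc(/C=C/c2cc(OC)cc(OC)c2/C=C/C(=O)c2ccc(C)cc2)cc1`, 4.8 ug/mL;
compound 2, `CCCCOc1ccc(C(=O)/C=C/c2c(/C=C/c3ccc(OC)cc3)cc(OC)cc2OC)cc1`, 12.9 ug/mL;
compound 3, `COc1ccc(/C=C/c2cc(OC)cc(OC)c2/C=C/C(=O)c2ccc(C(F)(F)F)cc2)cc1`, 18.7 ug/mL.

In a functional assay on HepG2 cells (Homo sapiens) for antiproliferative activity, read by MTT assay, with a stated time of 48 h (a higher number here means a weaker inhibitor, a lower number a stronger inhibitor), compound 1 gives the lowest of the three numbers, with compound 2 nearest and compound 3 furthest. Compound 4, `CCOc1ccc(C(=O)/C=C/c2c(/C=C/c3ccc(OC)cc3)cc(OC)cc2OC)cc1`, is not yet measured. It differs from compound 1 by ethoxy in place of methyl on an aromatic carbon. Among the measured compounds shown here, two measured steps bear on this change: a 2.7-fold higher number from compound 1 to compound 2 (0.43 log units; beyond the scatter), and a 3.9-fold higher number from compound 1 to compound 3 (0.59 log units; beyond the scatter). Both replacements of the methyl raised the number modestly, and the step from compound 2 to compound 3 stayed within the scatter. Ethoxy shares the oxygen and part of the chain of butoxy, so compound 4 is expected to show a 1.8-fold higher number from compound 1 to compound 4 (0.25 log units; within the scatter). The estimate for compound 4 is 8.5 ug/mL, ranging from 4.5 ug/mL to 16 ug/mL.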

Compound 4, half-maximal inhibitory concentration: 8 ug/mL
Compound 4: middle estimate off by 1.1-fold (0.03 log units), on the high side; measured number inside the range.
By their numbers in this assay, from the lowest: compounds 1, 4, 2 and 3 (each within the scatter of the next, the first and the last beyond it).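

In this assay, among the compounds shown here, ethoxy on the aromatic carbon para to a large group is the first replacement of the methyl that stays within the scatter, with a 1.7-fold higher number from compound 1 to compound 4 (0.22 log units; within the scatter) at this position. Ethoxy is likewise not separated from butoxy, with a 1.6-fold lower number from compound 2 to compound 4 (0.21 log units; within the scatter) here, whereas a 2.3-fold lower number from compound 3 to compound 4 (0.37 log units; beyond the scatter) sets it apart from trifluoromethyl. No measurement at hand gives a reason for these differences.

The compounds shown leave open how a hydroxyl, an amine or a carboxylic acid would compare with methyl at this position. They also leave open whether a chain longer than butoxy would raise the number further.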